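A Chloro-for-Methyl Swap on the Benzyloxy Arm

The source may report more compounds than this note shows. Statements on the series, on what has been measured and on what is new or still open speak of the compounds shown alone.

Compound 1, `FC(F)(F)c1ccc(CN2CCN(Cc3cc(-c4ccc(OCc5ccccc5)cc4)on3)CC2)cc1`, gives 2900 nM in a functional assay on MCF7 cells (Homo sapiens) for antiproliferative activity, read by sulforhodamine B assay, with a stated time of 72 h; on this read-out lower numbers stand for stronger inhibition and higher numbers for weaker inhibition.
Compound 2, `Cc1cccc(COc2ccc(-c3cc(CN4CCN(Cc5ccc(C(F)(F)F)cc5)CC4)no3)cc2)c1`, gives 4000 nM in this assay.

The two measured compounds share a core and differ only on the benzyloxy arm. The step of a 1.4-fold higher number from compound 1 to compound 2 (0.14 log units; within the scatter) came with methyl in place of hydrogen on an aromatic carbon. Going by the values given here, compound 2 thus carries the higher of the two numbers, with compound 1 as its only neighbour, but that gap is within the scatter, so no order between the two can be read from it.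

Compound 3, `FC(F)(F)c1ccc(CN2CCN(Cc3cc(-c4ccc(OCc5cccc(Cl)c5)cc4)on3)CC2)cc1`, is not yet measured. It differs from compound 2 by chloro in place of methyl on an aromatic carbon. Among the compounds with values here, no measured step exchanges chloro for methyl; the single step at hand touches the same place but with a different group, and it stayed within the scatter. The data give no ground for a shift beyond the scatter in either direction. For compound 3 the expected step in this assay is a 1.1-fold lower number from compound 2 to compound 3 (0.06 log units; within the scatter). The estimate for compound 3 is 3500 nM, with a range from 1500 nM to 8000 nM.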

Compound 3, half-maximal inhibitory concentration: 1400 nM
Compound 3: the middle estimate sits 2.5-fold (0.40 log units) above what was measured; the measured number lies below the stated range.
By their numbers in this assay, from the lowest: compound 3; then compounds 1 and 2 (each within the scatter of the next).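

In this assay, going by these compounds alone, chloro is the first group on this carbon of the benzyloxy arm to move the number beyond the scatter: exchanging methyl for chloro gives a 2.9-fold lower number from compound 2 to compound 3 (0.46 log units; beyond the scatter), and adding chloro in place of hydrogen gives a 2.1-fold lower number from compound 1 to compound 3 (0.32 log units; beyond the scatter), both modest in size. Methyl in place of hydrogen had stayed within the scatter, which on its own left open whether this place responded to any change at all; the new steps show that it can respond, and that the outcome depends on the group, since methyl and chloro, each a single heavy atom on the same carbon, do not give the same number. Nothing in the material at hand explains why the two groups part ways at this place.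

The compounds shown leave open whether this gain belongs to chloro alone or would also appear with fluoro, bromo, methoxy or a nitrile on the same carbon. They also leave open whether chloro would give a similar step on another carbon of this ring, or with a group other than trifluoromethyl on the far benzyl ring.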